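The source may hold more compounds than are shown below. What is called first, only, known or untested is meant among the compounds shown, and "the series" means these compounds.

Measured so far in a functional assay on HCT-116 cells (Homo sapiens) for inhibition, read by MTT assay, with a stated time of 48 h; a lower number here means a stronger inhibitor, a higher number a weaker inhibitor:
- compound 1 `CCCCC(=O)N(Cc1ccc(OC)c(O)c1)c1cc(OC)c(OC)c(OC)c1`: 170 nM
- compound 2 `COCC(=O)N(Cc1ccc(OC)c(O)c1)c1cc(OC)c(OC)c(OC)c1`: 230 nM

Among the measured compounds shown here, compound 2 stands at the high end of these two numbers, with compound 1 as its only neighbour; the one step between them, a 1.4-fold higher number from compound 1 to compound 2 (0.13 log units; within the scatter), is within the scatter, so the two cannot be ranked.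

Compound 3 `COc1ccc(CN(C(=O)C=C(C)C)c2cc(OC)c(OC)c(OC)c2)cc1O` is the next member, not yet measured in this assay. It differs from compound 2 by 2-methylprop-1-en-1-yl in place of methoxymethyl on a carbonyl carbon. For the measured compounds named here, only the step from compound 1 to compound 2 bears on an exchange at this carbonyl carbon, and that step stayed within the scatter. Going by the values given here, no measured step shows the effect of a 2-methylprop-1-en-1-yl group here. On this basis no step beyond the scatter is expected in this assay in either direction for compound 3; the expected step is a 1.2-fold lower number from compound 2 to compound 3 (0.06 log units; within the scatter). Compound 3 is therefore estimated at 200 nM, with a range of 80 nM to 500 nM.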

Compound 3, half-maximal inhibitory concentration: 290 nM
For compound 3 the middle estimate is 1.5-fold (0.16 log units) below the measured one, and the stated range covers the measured number.
By their numbers in this assay, from the lowest: compounds 1, 2 and 3 (each within the scatter of the next).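

In this assay, among the compounds shown here, the carbonyl carbon bound to the amide-type nitrogen accepts 2-methylprop-1-en-1-yl, the first group here with a double bond outside aromatic rings, in place of methoxymethyl with no step beyond the scatter: a 1.3-fold higher number from compound 2 to compound 3 (0.10 log units; within the scatter). Set against butyl the exchange reads the same, a 1.7-fold higher number from compound 1 to compound 3 (0.23 log units; within the scatter), so butyl, methoxymethyl and 2-methylprop-1-en-1-yl cannot be ranked at this place, and the series so far shows no sensitivity to these three groups there. No measurement is available that would explain this result.

From the compounds shown here alone, whether an amine, a carboxylic acid, a phenyl ring or a longer chain on this carbonyl carbon would give a step beyond the scatter remains open. Going by these compounds, the part played by the hydroxy and methoxy groups of the shared core also remains open, since all three compounds carry them unchanged.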